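Swapping the aryl group on a shared pyran core

The source may hold more compounds than are shown below. What is called first, only, known or untested is meant among the compounds shown, and "the series" means these compounds.

Compound 1 `COc1cc(Br)c(C2C(C#N)=C(N)OC(c3c[nH]c4ccccc34)=C2C#N)cc1OC` serves as the reference point for this series: in a functional assay, tested at 100 ug/mL (a higher number here means a stronger effect of the compound at the concentration tested, a lower number a weaker effect), compound 1 gives 20.5%. Compound 2 `N#CC1=C(N)OC(c2c[nH]c3ccccc23)=C(C#N)C1c1ccc2ccccc2c1` shares the same core but carries a naphthalen-2-yl group on the saturated ring carbon; in this assay compound 2 is recorded as "not active" (no number reported), so no single number stands for it and its standing can only be described as weak. Compound 3 `Cc1ccccc1C1C(C#N)=C(N)OC(c2c[nH]c3ccccc23)=C1C#N` differs from compound 2 by one change: 2-methylphenyl in place of naphthalen-2-yl on a saturated ring carbon. Among the measured compounds shown here, with no measured step between two compounds of this kind, the size of the change from compound 2 cannot be read from the data, and only a modest shift in this assay, if any beyond the scatter, is expected. On that basis compound 3 is estimated to give 10% in this assay, with a range from 0% to 30%.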

Compound 3, a percentage reported as activity, at one concentration (the size of the read-out at that concentration, not a potency): 17.2%
Compound 3: the middle estimate sits 7.2 percentage points below what was measured, within the range that was stated.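

Among the compounds shown here, compound 2 has no single number in this assay, and no step to compound 3 can be read from it. No evidence at hand bears on this result. The compounds shown leave open how much swapping naphthalen-2-yl for 2-methylphenyl changes the read-out.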